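The source may hold more compounds than are shown below. What is called first, only, known or untested is meant among the compounds shown, and "the series" means these compounds.

For the measured compounds named here, compound 1 `CC(C)COc1ncc(-c2cc(F)c(-c3nnc(S(=O)(=O)CC4CC4)[nH]3)cc2F)cc1Cl` gives 67 uL/min in an ADME assay on microsomes from liver (Homo sapiens) for metabolic stability (on this read-out lower numbers stand for slow clearance and higher numbers for fast clearance), the second highest of the three numbers measured so far: compound 2 `CC(C)COc1ncc(-c2cc(F)c(-c3nnc(S(C)(=O)=O)[nH]3)cc2F)cc1Cl` gives 41 uL/min, and compound 3 `CC(C)COc1ncc(-c2cc(F)c(-c3nnc(S(=O)(=O)NC4CC4)[nH]3)cc2F)cc1Cl` gives 125 uL/min. Neither neighbour separates from compound 1 beyond the scatter, as a 1.6-fold lower number from compound 1 to compound 2 (0.21 log units; within the scatter) and a 1.9-fold higher number from compound 1 to compound 3 (0.27 log units; within the scatter) show; only a 3.0-fold higher number from compound 2 to compound 3 (0.48 log units; beyond the scatter) passes it. Compound 4 `Cc1ccc(Cl)c(Oc2ncc(-c3cc(F)c(-c4nnc(S(=O)(=O)CC5CC5)[nH]4)cc3F)cc2Cl)c1` differs from compound 1 in one place: 2-chloro-5-methylphenyl in place of isobutyl on an oxygen on an aromatic ring. Every measured step alters the group on the sulfonyl sulfur, so none of them bears on this change at the oxygen, and no direction can be drawn from them. Relative to compound 1, the step expected for compound 4 is a 1.3-fold higher number from compound 1 to compound 4 (0.13 log units; within the scatter), with wide uncertainty. The estimate for compound 4 is 90 uL/min, ranging from 40 uL/min to 200 uL/min.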

Compound 4, intrinsic clearance in a liver preparation (reported as CLH), per the amount of preparation that the assay uses: 41 uL/min
For compound 4 the middle estimate is 2.2-fold (0.34 log units) above the measured one, and the stated range covers the measured number.
By their numbers in this assay, from the lowest: compounds 2, 4, 1 and 3 (each within the scatter of the next, the first and the last beyond it).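

For the compounds shown here, this step is the first to touch the group on the oxygen, as the earlier compounds differ only on the sulfonyl sulfur. In this assay, the step is a 1.6-fold lower number from compound 1 to compound 4 (0.21 log units; within the scatter), so exchanging the isobutyl chain for an aromatic ring does not separate the two compounds. Nothing shown explains this result. From the compounds shown here alone, what remains open is how a chain carrying an amine or a carboxylic acid would read at this oxygen, and whether the differences seen on the sulfonyl sulfur would persist with 2-chloro-5-methylphenoxy in place.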